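Compound 2 to compound 4: losing the ring

This account rests on a few compounds, and the source may have more. Where it says the series, first, only, none or still open, it means among the compounds named here.

compound 1 `Cc1cc(C)c(CN2CCc3c(Cl)cc([C@H](CO)[C@H]4CCOC4)c(Cl)c3C2=O)c(=O)[nH]1`: 15 nM
compound 2 `Cc1cc(C)c(CN2CCc3c(Cl)cc([C@H](CO)[C@H]4CCCO4)c(Cl)c3C2=O)c(=O)[nH]1`: 63 nM
compound 3 `COC(c1cc(Cl)c2c(c1Cl)C(=O)N(Cc1c(C)cc(C)[nH]c1=O)CC2)C1CCS(=O)(=O)CC1`: 970 nM; 24 nM (2 entries)

In a functional assay on KARPAS-422 cells (Homo sapiens) for antiproliferative activity, read by resazurin assay, with a stated time of 72 h (on this read-out higher numbers stand for weaker inhibition and lower numbers for stronger inhibition), compound 2 gives 63 nM, the higher of the two single numbers, and its nearest neighbour is compound 1 at 15 nM. Compound 3 offers no single number, and the record shows (the several entries of compound 3 in this assay, 970 nM; 24 nM (2 entries)).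

Compound 4 `Cc1cc(C)c(CN2CCc3c(Cl)cc([C@H](C)CO)c(Cl)c3C2=O)c(=O)[nH]1` has not yet been measured. The change leading to it from compound 2 is a group of 4 heavy atoms (3 carbon, 1 oxygen; no ring) in place of a group of 8 heavy atoms (6 carbon, 2 oxygen; one five-membered non-aromatic ring with 1 hetero atom), on an aromatic carbon. A 1-(hydroxymethyl)ethyl group thus stands on the aromatic carbon, and the five-membered non-aromatic ring is gone.

For the measured compounds named here, one measured step bears on this: a 4.2-fold higher number from compound 1 to compound 2 (0.62 log units; beyond the scatter). It moves only the attachment from oxolan-3-yl to oxolan-2-yl, yet it lies beyond the scatter, so the number does respond to changes in this group. Going by the values given here, no measured compound lacks the ring, so this step is only a loose guide, and the spread in compound 3 argues for a wide range. A modest move toward a higher number in this assay is expected, similar in size to that step. The expected step is a 2.4-fold higher number from compound 2 to compound 4 (0.38 log units; beyond the scatter). For compound 4 the estimated value is 150 nM, with an expected range from 40 nM to 550 nM.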

Compound 4, half-maximal inhibitory concentration: 186 nM
For compound 4 the middle estimate is 1.2-fold (0.09 log units) below the measured one; measured number inside the range.
By their numbers in this assay, from the lowest: compound 1; then compound 2; then compound 4.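

Read in this assay, these results give the first measure of what the five-membered non-aromatic ring adds at this position, on an aromatic carbon ortho to a chloro group: replacing the ring-bearing group with 1-(hydroxymethyl)ethyl gives a 3.0-fold higher number from compound 2 to compound 4 (0.47 log units; beyond the scatter). The same replacement measured against the other ring isomer gives a 12-fold higher number from compound 1 to compound 4 (1.09 log units; beyond the scatter), a step classed as large where the first is modest, so the size of the loss depends on which ring isomer is taken as the reference. Even so, the smaller group retains measurable antiproliferative activity, which shows that the ring improves the number here but is not needed for a reading in the nanomolar range.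

The compounds shown leave open whether an open-chain group carrying a methoxy ether, or a piperidine ring holding an amine in place of the ring oxygen, would recover the number of compound 1, and all three single-valued compounds keep the hydroxymethyl group, so its own share remains unknown. Compound 3 gives no single number to set against these results: the several entries of compound 3 in this assay, 970 nM; 24 nM (2 entries)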